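Methyl to Diethylsulfamoyl: Expected Cytotoxicity of Compound 4

A few compounds are considered here, and "the series" means these few. Any claim that something is new, unique, unknown or untested is made for them only; others in the source may bear on it.

Of the compounds shown here, three built on a shared core have been tested in an ADME assay on PC-3 cells (Homo sapiens) for cytotoxicity, read by WST assay, tested at 100 uM; a lower number here means less inhibition, a higher number more inhibition at the concentration tested (going by the name of the read-out). Compound 1 `O=C(Nc1cccc(N2CCCC2=O)c1)C1CCCN(C(=O)c2cc(C(F)(F)F)cc(C(F)(F)F)c2)C1` gives 0%. Compound 2 `Cc1cccc(C(=O)N2CCCC(C(=O)Nc3ccc(Cl)cc3)C2)c1` gives 0%. Compound 3 `Cn1cnnc1-c1cccc(NC(=O)C2CCCN(C(=O)c3cc(C(F)(F)F)cc(C(F)(F)F)c3)C2)c1` gives 0%. Among the measured compounds shown here, the only pair differing in a single place is covered by the step of no change at the digits printed from compound 1 to compound 3 (within the scatter), in which 4-methyl-4H-1,2,4-triazol-3-yl replaces 2-oxopyrrolidin-1-yl on an aromatic carbon; the read-out does not move. Compound 2 stands level with compound 1 and compound 3 at the digits shown, and its gaps to both lie within the scatter.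

Compound 4 `CCN(CC)S(=O)(=O)c1cccc(C(=O)N2CCCC(C(=O)Nc3ccc(Cl)cc3)C2)c1` has not yet been measured. It differs from compound 2 by diethylsulfamoyl in place of methyl on an aromatic carbon, the group sitting meta to a large group on a six-membered aromatic ring of carbon only. For the measured compounds named here, no measured step touches this position; the one step available, no change at the digits printed from compound 1 to compound 3 (within the scatter), concerns a different aromatic carbon and was flat. Every measured compound sits at the bottom of the read-out, so nothing in the set points to a rise. The step of no change at the digits printed from compound 2 to compound 4 (within the scatter) is therefore expected to stay within the scatter. Compound 4 is estimated at 0%, with a range from 0% to 15%.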

Compound 4, a percentage reported as inhibition, at one concentration (the size of the read-out at that concentration, not a potency): 0%
Compound 4: the middle estimate sits on the measured number at the digits printed; the measured number falls inside the stated range.
By their numbers in this assay, from the lowest: compounds 1, 2, 3 and 4 (each within the scatter of the next).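

In this assay, this position now has its first measured step, and it reads no change at the digits printed from compound 2 to compound 4 (within the scatter), even though the change is a large one: methyl, with 1 heavy atom and 0 hydrogen-bond acceptors, gives way to diethylsulfamoyl, with 8 heavy atoms and 2 hydrogen-bond acceptors. Among the compounds shown here, the earlier compounds showed a flat step only on a different aromatic carbon, so this is the first sign that a much bigger group on this carbon, meta to a large group, can leave the read-out level. Compound 2 already stood at the bottom of the read-out, however, so a fall could not have shown up here, and the result speaks only against a rise; nothing available explains the flat step at this position.

On these data alone, it remains open whether a carboxylic acid or a primary amine on this same aromatic carbon would also leave the read-out level. As far as these compounds go, it is also open whether diethylsulfamoyl would give the same result on the core of compound 1, which carries two trifluoromethyl groups in place of the single substituent studied here.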